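The compounds below may be only part of what the source reports. "The series", "measured", "known", "first", "only" and "open" are said of these compounds alone.

Compound 1, `CSCC[C@H](NC(=O)c1ccc(NCc2cncn2Cc2ccccc2C)cc1-c1ccccc1)C(=O)O`, is an acid bearing a methyl group on its benzyl ring. In a functional assay on NIH3T3 cells (Mus musculus) (a higher number here means that more compound is needed for the effect, a lower number that less compound is needed), compound 1 reaches only the limit of > 10 uM, not a number. Compound 2, `COC(=O)[C@H](CCSC)NC(=O)c1ccc(NCc2cncn2Cc2ccccc2Cl)cc1-c1ccccc1`, carries the methyl ester and a chlorine instead. In this assay compound 2 likewise stops at the limit of > 10 uM, so both values rest at the limit of > 10 uM in this assay, at which 2 of the 2 values shown sit. Compound 3, `CSCC[C@H](NC(=O)c1ccc(NCc2cncn2Cc2ccccc2Cl)cc1-c1ccccc1)C(=O)O`, arises from compound 2 by hydrogen in place of methyl on an oxygen next to a carbonyl group. Since no step between measured compounds is shown, the step from compound 2 to compound 3 is expected to be a step that the limit leaves unreadable from compound 2 to compound 3, none beyond the scatter, given (the limit of > 10 uM in this assay, at which 2 of the 2 values shown sit). Compound 3 is therefore estimated at 20 uM, within 8 uM to 100 uM.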

Compound 3, concentration for half-maximal effect: > 10 uM
Compound 3 gave a limit, no number; the forecaster's own chance of this, stated with the estimate: 80%; the middle value does not contradict the limit.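

For the compounds shown here, compound 3 gives > 10 uM in this assay, again a limit and not a number, and no step to compound 3 from compound 1 or compound 2 can be read. The compounds shown leave open how much of any of the three is needed for the effect, and whether either single change alters it.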